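This account rests on a few compounds, and the source may have more. Where it says the series, first, only, none or still open, it means among the compounds named here.

Measured in a functional assay on A2780 cells (Homo sapiens) for inhibition; on this read-out lower numbers stand for stronger inhibition and higher numbers for weaker inhibition:
- compound 1 `CCNC(=O)c1noc(-c2cc(C(C)C)c(O)cc2O)c1-c1ccn(C)n1`: 12 nM
- compound 2 `CCCn1ccc(-c2c(C(=O)NCC)noc2-c2cc(C(C)C)c(O)cc2O)n1`: 27 nM

Going by the values given here, compound 2 holds the higher of the two numbers, and compound 1 is its only neighbour. Compound 3 `CCNC(=O)c1noc(-c2cc(C(C)C)c(O)cc2O)c1-c1cnn(C(C)C)c1` is not yet measured and differs from compound 2 thus: 1-isopropyl-1H-pyrazol-4-yl in place of 1-propyl-1H-pyrazol-3-yl on an aromatic carbon. Among the compounds with values here, the one measured step, a 2.3-fold higher number from compound 1 to compound 2 (0.35 log units; beyond the scatter), is modest and bears only in part, since no measured compound carries the 1-isopropyl-1H-pyrazol-4-yl group. A change of similar modest size is therefore expected, with no direction fixed by the data. The expected change is a 1.4-fold lower number from compound 2 to compound 3 (0.13 log units; within the scatter). For compound 3 the estimate is 20 nM, with an expected range of 6 nM to 70 nM.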

Compound 3, half-maximal inhibitory concentration: 21 nM
For compound 3 the middle estimate is 1.1-fold (0.02 log units) below the measured one; low and high end bracket the measured number.
By their numbers in this assay, from the lowest: compounds 1, 3 and 2 (each within the scatter of the next, the first and the last beyond it).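

In this assay, 1-isopropyl-1H-pyrazol-4-yl in place of 1-propyl-1H-pyrazol-3-yl gives a result within the scatter (a 1.3-fold lower number from compound 2 to compound 3 (0.11 log units; within the scatter)), and in place of 1-methyl-1H-pyrazol-3-yl it also gives a result within the scatter (a 1.8-fold higher number from compound 1 to compound 3 (0.24 log units; within the scatter)). This aromatic carbon, next to the ring atom that bears an ethylcarbamoyl group, therefore carries a pyrazol-4-yl group as well as a pyrazol-3-yl group with neither step beyond the scatter. Nothing available explains this result.

The attachment point and the branched chain change together in compound 3, so their separate contributions remain unresolved. Also open, as far as these compounds go, is whether 1-propyl-1H-pyrazol-4-yl, or a pyrazole whose nitrogen chain ends in an amine or a carboxylic acid, would fall in the same range.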